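This account rests on a few compounds, and the source may have more. Where it says the series, first, only, none or still open, it means among the compounds named here.

Measured in a functional assay on the whole organism (strain albino) for inhibition, with Rattus norvegicus as the target, read by paw edema, with stated times of 30 min and 2 h, at a dose of 0.28 mmol/kg by the oral route; on this read-out higher numbers stand for more inhibition at the one dose given (going by the name of the read-out) and lower numbers for less inhibition:
- compound 1 `CCn1c(SCC(=O)Nc2ccc(C(C)=O)cc2)nnc1-c1ccc(OC)c(OC)c1` gives 59%
- compound 2 `C=CCn1c(SCC(=O)Nc2ccc(C(C)=O)cc2)nnc1-c1ccc(OC)c(OC)c1` gives 57%
- compound 3 `CCn1c(SCC(=O)Nc2ccc(C(C)=O)cc2)nnc1-c1ccc(OC)cc1` gives 54%

Compound 3 holds the lowest of the three numbers, but its gaps to the other two are within the scatter: the step of a number 5 percentage points lower from compound 1 to compound 3 (within the scatter) is small, and compound 2 sits only slightly above compound 3. No order among the three can be read from these values.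

Compound 4 `C=CCn1c(SCC(=O)Nc2ccc(C(C)=O)cc2)nnc1-c1ccc(OC)cc1` is not yet measured. It differs from compound 3 by vinyl in place of methyl on a saturated chain carbon bound to an aromatic nitrogen. Within the data shown here, the one step that bears directly on this change is a number 2 percentage points lower from compound 1 to compound 2 (within the scatter), the same exchange on the dimethoxy partner, and it did not move the read-out beyond the scatter. The step of a number 5 percentage points lower from compound 1 to compound 3 (within the scatter) shows that the methoxy removal which separates compound 3 from compound 1 was also small, so nothing in the series suggests the two changes act together.

For compound 4 the expected step is a number 2 percentage points lower from compound 3 to compound 4 (within the scatter), i.e. no change beyond the scatter. Compound 4 is therefore estimated at 52%, with a range from 42% to 62%.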

Compound 4, a percentage reported as inhibition, in the whole organism at one dose (the size of the read-out at that dose, not a potency): 51%
Estimate against measurement, compound 4: 1 percentage points above; the measured number falls inside the stated range.
By their numbers in this assay, from the lowest: compounds 4, 3, 2 and 1 (each within the scatter of the next).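

The ethyl to allyl change can now be read on a second core in this assay, and with a number 3 percentage points lower from compound 3 to compound 4 (within the scatter) it stays as small without the second methoxy as with it: the same change on two cores in this assay, a number 2 percentage points lower (within the scatter) from compound 1 to compound 2 and a number 3 percentage points lower (within the scatter) from compound 3 to compound 4, 1 percentage points apart, within the scatter of two such steps. Hydrogen in place of methoxy on an aromatic carbon can likewise be read on the allyl partner, with a number 6 percentage points lower from compound 2 to compound 4 (within the scatter) matching its size on the ethyl partner: the same change on two cores in this assay, a number 5 percentage points lower (within the scatter) from compound 1 to compound 3 and a number 6 percentage points lower (within the scatter) from compound 2 to compound 4, 1 percentage points apart, within the scatter of two such steps. Each change therefore reads alike whether or not the other is in place, and these four compounds give no sign of the two acting together.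

Neither change has yet moved the inhibition beyond the scatter, so these compounds mark no group at either place as one that matters. Open, as far as these compounds go, is whether a longer chain such as butyl or a benzyl group on the aromatic nitrogen, or chlorine or hydroxyl in place of methoxy, would do so.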